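The source may report more compounds than this note shows. Statements on the series, on what has been measured and on what is new or still open speak of the compounds shown alone.

Measured so far:
compound 1, `O=C(Nc1cccc(-n2cc(-c3ccncc3)c(-c3cc(O)cc(Cl)c3)n2)c1)Nc1ccc(Cl)c(Cl)c1`: in a functional assay on PC-3 cells (Homo sapiens) for inhibition, read by sulforhodamine B assay, with a stated time of 48 h, tested at 1 uM (a lower number here means a stronger effect, a higher number a weaker effect of the compound at the concentration tested), compound 1 gives 72%
compound 2, `COc1cc(Cl)cc(-c2nn(-c3cccc(NC(=O)Nc4ccc(Cl)c(Cl)c4)c3)cc2-c2ccncc2)c1`: compound 2 gives 54%

For the measured compounds named here, compound 2 has the lower of the two numbers; the only measured step, a number 18 percentage points lower from compound 1 to compound 2 (beyond the scatter), comes from a methyl in place of hydrogen on an oxygen on an aromatic ring. Compound 3, `COc1cc(Cl)cc(-c2nn(-c3cccc(NC(=O)c4cccc(C(F)(F)F)c4)c3)cc2-c2ccncc2)c1`, has not been measured. It differs from compound 2 in one place: 3-(trifluoromethyl)phenyl in place of (3,4-dichlorophenyl)amino on a carbonyl carbon. The measured step touches a different part of the shared core, so nothing measured bears on this change. For compound 3 the number is therefore expected near compound 2 with a wide range, about 65% (from 40% to 95%), a step of a number 11 percentage points higher from compound 2 to compound 3 (beyond the scatter) is expected.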

Compound 3, a percentage reported as activity, at one concentration (the size of the read-out at that concentration, not a potency): 73%
For compound 3 the middle estimate is 8 percentage points below the measured one; the range from low to high includes it.
By their numbers in this assay, from the lowest: compound 2; then compounds 1 and 3 (each within the scatter of the next).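

In this assay, the group on the carbonyl carbon proves to matter: 3-(trifluoromethyl)phenyl in place of (3,4-dichlorophenyl)amino gives a number 19 percentage points higher from compound 2 to compound 3 (beyond the scatter), a weaker effect at the concentration tested. This single swap removes the amino nitrogen with its hydrogen-bond donor and also changes the substituents on the ring, so the two changes cannot be told apart. Nothing available explains the shift.

Going by these compounds, it remains open which of the two changes carries the difference, and a (3-(trifluoromethyl)phenyl)amino group on the same carbonyl carbon would help separate them. On these data alone, how a plain methyl on that carbonyl carbon would compare also remains open.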